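A Methoxy Group Removed in Two Settings

A few compounds are considered here, and "the series" means these few. Any claim that something is new, unique, unknown or untested is made for them only; others in the source may bear on it.

Of the compounds shown here, three have so far been measured in a functional assay on HCC 2998 cells (Homo sapiens) for cytotoxicity, read by sulforhodamine B assay, with a stated time of 48 h, tested at 0.01 uM; on this read-out lower numbers stand for a stronger effect and higher numbers for a weaker effect at the one concentration tested. Compound 1 `COc1ccc(-c2cc(/C=C/C(=O)c3ccc(N)cc3)[nH]n2)cc1` gives 96% in this assay. Compound 2 `COc1ccc(-c2cc(/C=C/C(=O)c3ccc(N)cc3)[nH]n2)cc1OC` gives 102%, and compound 3 `COc1cc(C(=O)/C=C/c2cc(-c3cc(OC)c(OC)c(OC)c3)n[nH]2)cc(OC)c1OC` gives 102%. How the cores of compound 2 and compound 3 differ is not broken down here; their two values are level at the digits printed, and together they are the highest of the three numbers, with compound 1 lying within the scatter of both.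

Between compound 2 and compound 1 a single change is made: hydrogen in place of methoxy on an aromatic carbon. This step amounts to a number 6 percentage points lower from compound 2 to compound 1 (within the scatter).

Compound 4 `COc1ccc(-c2cc(/C=C/C(=O)c3cc(OC)c(OC)c(OC)c3)[nH]n2)cc1OC` has not yet been measured. It differs from compound 3 by hydrogen in place of methoxy on an aromatic carbon. Among the compounds with values here, this is the same kind of change as the one from compound 2 to compound 1, but not the same change: in compound 3 the place is also meta to a methoxy group, whereas in compound 2 it is only ortho to a methoxy group and meta to a large group.

Within the data shown here, the expectation rests on the one measured instance, because the same kind of change gave a number 6 percentage points lower from compound 2 to compound 1 (within the scatter) and nothing among the measured compounds points another way. The step to compound 4 is therefore expected to be a number 4 percentage points lower from compound 3 to compound 4 (within the scatter). In this assay compound 4 is estimated to give 98%, with the estimate spanning from 86% to 108%.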

Compound 4, a percentage reported as activity, at one concentration (the size of the read-out at that concentration, not a potency): 95%
Beside the measured number, compound 4's estimate is 3 percentage points above it, within the range that was stated.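

Compound 4 carries hydrogen where compound 3 carries a methoxy group, and in this assay this amounts to a number 7 percentage points lower from compound 3 to compound 4 (within the scatter). Set beside the earlier instance, the change reads alike on the two cores, so in this small set it carries from one to the other without a detectable difference: the same change on two cores in this assay, a number 6 percentage points lower (within the scatter) from compound 2 to compound 1 and a number 7 percentage points lower (within the scatter) from compound 3 to compound 4, 1 percentage points apart, within the scatter of two such steps. This agreement is limited, however: both steps lie within the scatter and come from a single concentration, so they do not show that removing the methoxy group has any real effect on the read-out, and two cores give no basis for a rule that would hold on other cores in the series.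

The compounds shown leave open what other groups would do at this place on the aromatic ring, such as a hydroxyl group, a fluorine atom, a nitrile or a carboxylic acid in place of the methoxy group. They also leave open whether the two cores would still respond alike to this change at a concentration where this assay gives numbers that stand clearly apart from one another.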